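Swapping the alkyl chain of compound 2 for an amino group

The source may hold more compounds than are shown below. What is called first, only, known or untested is meant among the compounds shown, and "the series" means these compounds.

Three members of the series have been measured in an assay on IMR-32 cells for displacement of a labelled ligand from corticotropin-releasing factor receptor 1 (Homo sapiens), read by scintillation counting, with a stated time of 2 h; on this read-out lower numbers stand for stronger inhibition and higher numbers for weaker inhibition. Among the compounds with values here, compound 1 `CCC(CC)Nc1nc(OC)c(-c2ccc(Cl)cc2Cl)nc1C` gives 14.4 nM, and compound 3 `CCC(CC)Nc1nc(OC)c(-c2ccc(Cl)cc2Cl)nc1OC` gives 8.4 nM; the only single-point step between measured compounds, a 1.7-fold lower number from compound 1 to compound 3 (0.23 log units; within the scatter), lies within the scatter. Compound 2 `CCc1nc(-c2ccc(Cl)cc2Cl)c(CC)nc1CC(CC)CC` gives 68 nM, the highest number of the three, beyond the scatter from both compound 1 and compound 3.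

Compound 4 `CCc1nc(-c2ccc(Cl)cc2Cl)c(CC)nc1NC(CC)CC` has not been measured. Relative to compound 2 the change is (pentan-3-yl)amino in place of 2-ethylbutyl on an aromatic carbon. Within the data shown here, no measured step covers this exchange; the one step on record, from compound 1 to compound 3, concerns a different position and is small. What the numbers do show is that compound 1 and compound 3, both carrying the (pentan-3-yl)amino group, sit well below compound 2, although they also differ from compound 2 at two further ring positions, so the comparison is not clean.

On that basis a step to a lower number is expected, of about a 3.4-fold lower number from compound 2 to compound 4 (0.53 log units; beyond the scatter). For compound 4 the expected value in this assay is 20 nM, with a plausible range from 6 nM to 60 nM.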

Compound 4, inhibition constant: 4.1 nM
Estimate against measurement, compound 4: 4.9-fold (0.69 log units) above, and the stated range ends above it.
By their numbers in this assay, from the lowest: compound 4; then compounds 3 and 1 (each within the scatter of the next); then compound 2.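

In this assay, the exchange of 2-ethylbutyl for (pentan-3-yl)amino on the aromatic carbon para to the 2,4-dichlorophenyl group gives a 17-fold lower number from compound 2 to compound 4 (1.22 log units; beyond the scatter) as a large step beyond the scatter. Within the data shown here, this is the one reading of the amino group at this position with the rest of the structure held constant, which the earlier comparison of compound 2 with compound 1 and compound 3 could not give. Both groups have 6 heavy atoms, so the step comes with a change in make-up rather than in heavy-atom count: one carbon is replaced by 1 nitrogen, and the entering group has 1 hydrogen-bond donor and 1 hydrogen-bond acceptor, while the leaving group has neither. No measurement in hand explains the size of this step.

Open, going by these compounds, is whether the lower number depends on the amine hydrogen, a question that an N-methyl tertiary amine or a pentan-3-yloxy ether at this position would address. Among these compounds, compound 4 differs from compound 1 and compound 3 in more than one place, so no step to either can be read, and the contribution of the two ethyl groups remains unresolved.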